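The compounds below may be only part of what the source reports. "The series", "measured", "known", "first", "only" and "open" are said of these compounds alone.

In a functional assay on A549 cells (Homo sapiens) for antiproliferative activity, read by MTT assay, with a stated time of 48 h (a higher number here means a weaker inhibitor, a lower number a stronger inhibitor), compound 3 `O=c1cc(-n2cc(COc3ccc(F)cc3)nn2)c2ccccc2o1` gives 680 nM, the lowest of the three numbers. Compound 2 `O=c1cc(-n2cc(COc3ccc(F)cc3)nn2)c2cc(Br)ccc2o1` gives 850 nM in this assay, and the step of a 1.3-fold lower number from compound 2 to compound 3 (0.10 log units; within the scatter) shows nothing beyond the scatter between bromo and hydrogen on that aromatic carbon. Compound 1 `O=c1cc(-n2cc(COc3ccnc4ccc(Br)cc34)nn2)c2cc(Br)ccc2o1` gives 13300 nM, a number far beyond the scatter from compound 3. Compound 4 `COc1ccc2oc(=O)cc(-n3cc(COc4ccc(F)cc4)nn3)c2c1` is not yet measured in this assay; it differs from compound 3 by methoxy in place of hydrogen on an aromatic carbon. For the measured compounds named here, the only measured step that bears on changing a substituent at this carbon is a 1.3-fold lower number from compound 2 to compound 3 (0.10 log units; within the scatter), which stayed within the scatter, so the expected step is a 1.0-fold higher number from compound 3 to compound 4 (0.01 log units; within the scatter), none beyond the scatter. Compound 4 is therefore estimated at 700 nM, with a range from 300 nM to 1600 nM.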

Compound 4, half-maximal inhibitory concentration: 3150 nM
The estimate for compound 4 lay 4.5-fold (0.65 log units) below the measured number, outside the stated range (above it).
By their numbers in this assay, from the lowest: compounds 3 and 2 (each within the scatter of the next); then compound 4; then compound 1.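

In this assay this aromatic carbon turns out not to be indifferent to its substituent: putting methoxy in place of hydrogen gives a 4.6-fold higher number from compound 3 to compound 4 (0.67 log units; beyond the scatter), and putting methoxy in place of bromo gives a 3.7-fold higher number from compound 2 to compound 4 (0.57 log units; beyond the scatter). Bromo and hydrogen had not been told apart here, so methoxy is the first group at this carbon to separate from the others. Nothing shown gives a reason for this.

As far as these compounds go, whether a hydroxyl, an amine or a longer chain such as ethoxy at this carbon would go with methoxy or with hydrogen and bromo stays open. So does whether the methoxy step would hold on the core of compound 1.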